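The source may hold more compounds than are shown below. What is called first, only, known or untested is meant among the compounds shown, and "the series" means these compounds.

Three compounds sharing one core were tested in a functional assay on K562 cells (Homo sapiens) for inhibition, read by sulforhodamine B assay, with a stated time of 48 h; on this read-out higher numbers stand for weaker inhibition of growth and lower numbers for stronger inhibition of growth. Compound 1 `CC1=CC[C@H](C(C)(C)NC(=S)N/N=C/c2ccc(O)cc2)CC1` carries a 4-hydroxyphenyl group on a carbon with a double bond to nitrogen. In this assay compound 1 reaches only the limit of the assay, > 100000 nM, and no number. Compound 2 `CC1=CC[C@H](C(C)(C)NC(=S)N/N=C/c2ccccc2O)CC1` carries 2-hydroxyphenyl in place of 4-hydroxyphenyl on that carbon. In this assay compound 2 likewise stops at the assay limit, > 100000 nM. Compound 3 `CC1=CC[C@H](C(C)(C)NC(=S)N/N=C/c2ccccc2[N+](=O)[O-])CC1` carries nitro in place of hydroxy on an aromatic carbon. In this assay compound 3 also sits at the limit, > 100000 nM. The step that the two limits leave unreadable from compound 1 to compound 2 and the step that the two limits leave unreadable from compound 2 to compound 3 cannot be read, since both ends rest on (the limit of > 100000 nM in this assay, at which 3 of the 3 values shown sit). Compound 2 thus stands at the assay limit, where all three values shown sit, so no ordering among them is possible.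

Compound 4 `CC1=CC[C@H](C(C)(C)NC(=S)N/N=C/c2ccco2)CC1` differs from compound 2 by furan-2-yl in place of 2-hydroxyphenyl on a carbon with a double bond to nitrogen. Among the measured compounds shown here, no measured step bears on this change in a readable way: the two steps touching compound 2 are unreadable, and every value shown rests on (the limit of > 100000 nM in this assay, at which 3 of the 3 values shown sit). The expected step of a number no higher from compound 2 to compound 4 (the limit leaves the size open) is therefore one that cannot be resolved, with compound 4 expected to remain at the limit. Compound 4 is expected to give 100000 nM in this assay, in a range from 30000 nM to 100000 nM.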

Compound 4, concentration for total growth inhibition: > 100000 nM
Compound 4: a limit, no number; the forecaster's own chance of this, stated with the estimate: 85%; the middle value sits exactly at the limit.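

In this assay compound 4 gives > 100000 nM, a limit of the assay and not a number. The steps from compound 1 and from compound 2 to compound 4 therefore cannot be read: the limit of > 100000 nM in this assay, at which 4 of the 4 values shown sit. The compounds shown leave open which change to the shared core, if any, would give a measurable value.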